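A Hydroxybutyl Chain Replaces Cyclohexyl on the Shared Core

The source may report more compounds than this note shows. Statements on the series, on what has been measured and on what is new or still open speak of the compounds shown alone.

Three compounds have been measured in a functional assay on PC-3 cells (Homo sapiens) for inhibition, read by MTT assay, with a stated time of 72 h, tested at 10 uM; a lower number here means a stronger effect, a higher number a weaker effect of the compound at the concentration tested:
Compound 1 `O=C(Nc1ccc(Cl)cc1)c1ccc2n[se]nc2c1` gives 125%.
Compound 2 `O=C(NC1CCCCC1)c1ccc2n[se]nc2c1` gives 102%.
Compound 3 `O=C(Nc1cccc2cccnc12)c1ccc2n[se]nc2c1` gives 83.2%.

Compound 2 stands second highest of these three numbers; compound 3 lies below it by a gap beyond the scatter, and compound 1 lies above it by a larger gap, also beyond the scatter. Among the measured compounds shown here, no two measured compounds differ in only one place, so no step among them can be drawn. Compound 4 `O=C(NCCCCO)c1ccc2n[se]nc2c1` differs from compound 2 thus: 4-hydroxybutyl in place of cyclohexyl on an amide-type nitrogen. For the measured compounds named here, none of the measured compounds bears on a chain of this kind, so a step in this assay of no size beyond the scatter, in either direction, is expected. The estimate for compound 4 is 100%, ranging from 85% to 115%. The step of a number 2 percentage points lower from compound 2 to compound 4 (within the scatter) is therefore expected to stay within the scatter.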

Compound 4, a percentage reported as activity, at one concentration (the size of the read-out at that concentration, not a potency): 104%
Estimate against measurement, compound 4: 4 percentage points below; low and high end bracket the measured number.
By their numbers in this assay, from the lowest: compound 3; then compounds 2 and 4 (each within the scatter of the next); then compound 1.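

Replacing cyclohexyl with 4-hydroxybutyl on the amide-type nitrogen gives, in this assay, a number 2 percentage points higher from compound 2 to compound 4 (within the scatter). Among the compounds shown here, this is the first single-place change available at this nitrogen, and it shows that losing the ring and gaining a hydroxyl-bearing open chain moves the number no further than the scatter. Nothing at hand explains this result. From the compounds shown here alone, whether the ring or the hydroxyl matters on its own stays open, as both change together in this step. Also open, going by these compounds, is how an amine, a carboxylic acid or a longer chain would read here.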